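From methylcarbamoyl to a methoxycarbonyl-ethenyl chain

A few compounds are considered here, and "the series" means these few. Any claim that something is new, unique, unknown or untested is made for them only; others in the source may bear on it.

Compound 3 `CNC(=O)Cn1c(=O)c(C)cn([C@@H]2O[C@H](CO[Si](C)(C)C(C)(C)C)[C@@]3(OS(=O)(=O)C=C3N)[C@H]2O[Si](C)(C)C(C)(C)C)c1=O` stands at >= 250000 nM in a functional assay on CCRF-CEM cells (Homo sapiens) (on this read-out higher numbers stand for lower toxicity in this test and lower numbers for higher toxicity in this test), which is a limit of the assay. Compound 1 `COC(=O)Cn1c(=O)c(C)cn([C@@H]2O[C@H](CO[Si](C)(C)C(C)(C)C)[C@@]3(OS(=O)(=O)C=C3N)[C@H]2O[Si](C)(C)C(C)(C)C)c1=O` gives > 152000 nM, also a limit. Compound 2 `Cc1cn([C@@H]2O[C@H](CO[Si](C)(C)C(C)(C)C)[C@@]3(OS(=O)(=O)C=C3N)[C@H]2O[Si](C)(C)C(C)(C)C)c(=O)n(Cc2ccccc2)c1=O` gives 53000 nM. Compound 4 `COC(=O)/C=C/Cn1c(=O)c(C)cn([C@@H]2O[C@H](CO[Si](C)(C)C(C)(C)C)[C@@]3(OS(=O)(=O)C=C3N)[C@H]2O[Si](C)(C)C(C)(C)C)c1=O` differs from compound 3 at a saturated chain carbon bound to an aromatic nitrogen (2-(methoxycarbonyl)ethenyl in place of methylcarbamoyl on a saturated chain carbon bound to an aromatic nitrogen). Two measured changes at that carbon lie beyond the scatter: an at least 2.8-fold lower number from compound 1 to compound 2 (0.45 log units; beyond the scatter) and an at least 4.7-fold higher number from compound 2 to compound 3 (0.67 log units; beyond the scatter). The change a step that the two limits leave unreadable from compound 1 to compound 3 cannot be sized. Compound 4 keeps the methoxycarbonyl of compound 1 and lacks the phenyl of compound 2, so a position near these limits is expected, with some pull toward lower numbers. The expected change is an at least 2.5-fold lower number from compound 3 to compound 4 (0.39 log units; beyond the scatter), a modest move to a lower number. The estimate for compound 4 is 100000 nM, with an expected range of 35000 nM to 250000 nM.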

Compound 4, half-maximal cytotoxic concentration: 142000 nM
Compound 4: the middle estimate sits 1.4-fold (0.15 log units) below what was measured, within the range that was stated.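

In this assay, 2-(methoxycarbonyl)ethenyl in place of phenyl at this saturated chain carbon gives a readable step beyond the scatter, a 2.7-fold higher number from compound 2 to compound 4 (0.43 log units; beyond the scatter), so this position now has a second measured number that is not a limit. The comparison with the methoxycarbonyl group yields only a floor, an at least 1.0-fold lower number from compound 1 to compound 4 (0.02 log units; that floor lies within the scatter), because it rests on a limit: the limit of > 152000 nM in this assay, at which 1 of the 4 values shown sits. The comparison with methylcarbamoyl also yields only a floor, an at least 1.7-fold lower number from compound 3 to compound 4 (0.24 log units; that floor lies within the scatter), because it too rests on a limit: the limit of >= 250000 nM in this assay, at which 1 of the 4 values shown sits.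

Open, on these data alone, is how a carboxylic acid in place of the methyl ester of the 3-(methoxycarbonyl)prop-2-en-1-yl chain would read. As far as these compounds go, an amine at the end of a longer chain also remains open.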